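A few compounds are considered here, and "the series" means these few. Any claim that something is new, unique, unknown or untested is made for them only; others in the source may bear on it.

The measured compounds:
Compound 1, `CC1CCCc2c1[nH]c(=O)c(C#N)c2-c1cccn1C`, gives > 100000 nM in a functional assay on MDA-MB-231 cells (Homo sapiens) for inhibition, read by sulforhodamine B assay, with a stated time of 48 h; on this read-out higher numbers stand for weaker inhibition of growth and lower numbers for stronger inhibition of growth.
Compound 2, `COc1ccc(-c2cc(-c3cccn3C)c(C#N)c(N)n2)cc1OC`, gives 38000 nM in this assay.
Compound 3, `Cn1cccc1-c1cc(-c2cccs2)[nH]c(=O)c1C#N`, gives > 100000 nM in this assay.

For compound 3 the figure is not a number but a limit of the assay. Compound 3 thus stands at the weak end of what has been measured, sitting at the limit of > 100000 nM in this assay, at which 2 of the 3 values shown sit, together with compound 1, while compound 2 alone gives a numerical value. Compound 4, `Cn1cccc1-c1cc(-c2ccccc2)[nH]c(=O)c1C#N`, has not yet been measured. It differs from compound 3 in one place: phenyl in place of thiophen-2-yl on an aromatic carbon. Among the compounds with values here, no pair of measured compounds differing in just one place exists here, so nothing shows how such a swap moves the read-out. The change exchanges one aromatic ring for another without altering the charge, and the expectation in this assay is a step no larger than the scatter, in no particular direction. Compound 4 is therefore estimated to give about 100000 nM in this assay, within 30000 nM to 300000 nM, which means an expected step of a number no higher from compound 3 to compound 4 (the limit leaves the size open).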

Compound 4, concentration for 50% growth inhibition: 83200 nM
Estimate against measurement, compound 4: 1.2-fold (0.08 log units) above; the measured number falls inside the stated range.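

In this assay, within the data shown here, phenyl in place of thiophen-2-yl on this aromatic carbon, next to the ring nitrogen, gives the first single change that can be followed here, with an at least 1.2-fold lower number from compound 3 to compound 4 (0.07 log units; that floor lies within the scatter) as its step. Compound 3 gives > 100000 nM as a limit of the assay and not a number. Only a floor for the step can be read, and it does not show that exchanging one aromatic ring for the other matters, because compound 3 sits at that limit: the limit of > 100000 nM in this assay, at which 2 of the 4 values shown sit.

The compounds shown leave open whether something other than an aromatic ring on this carbon, such as an amine, a carboxylic acid or a longer alkyl chain, would move the number. They also leave open what a chlorine atom on the phenyl ring of compound 4 would do.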